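Methoxy for fluoro on the far ring of compound 3

The source may report more compounds than this note shows. Statements on the series, on what has been measured and on what is new or still open speak of the compounds shown alone.

Going by the values given here, in a functional assay on NCI-H460 cells (Homo sapiens) for cytotoxicity, read by MTT assay, with a stated time of 72 h (on this read-out lower numbers stand for stronger inhibition and higher numbers for weaker inhibition), compound 3 `COc1cc2c(Oc3ccc(NC(=O)c4cc(-c5ccc(F)cc5)ccn4)cc3F)ccnc2cc1OCCCN1CCCC1` gives 370 nM, the highest of the three numbers so far, yet it sits close to its neighbours. Compound 1 `COc1cc2c(Oc3ccc(NC(=O)c4cc(-c5ccc(F)cc5)ccn4)cc3F)ccnc2cc1OCCCN1CCCCC1` gives 250 nM, and the step of a 1.5-fold higher number from compound 1 to compound 3 (0.17 log units; within the scatter) lies within the scatter. Compound 2 `COc1ccc(-c2ccnc(C(=O)Nc3ccc(Oc4ccnc5cc(OCCCN6CCCCC6)c(OC)cc45)c(F)c3)c2)cc1` gives 200 nM, again within the scatter of the value of compound 3.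

Compound 4 `COc1ccc(-c2ccnc(C(=O)Nc3ccc(Oc4ccnc5cc(OCCCN6CCCC6)c(OC)cc45)c(F)c3)c2)cc1` differs from compound 3 by methoxy in place of fluoro on an aromatic carbon. This same exchange has been seen once in this assay, as a 1.3-fold lower number from compound 1 to compound 2 (0.10 log units; within the scatter), a move within the scatter. Carried over, the expected step is a 1.2-fold lower number from compound 3 to compound 4 (0.09 log units; within the scatter), which is no clear change. Compound 4 is therefore estimated at 300 nM, with an expected range from 150 nM to 600 nM.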

Compound 4, half-maximal inhibitory concentration: 200 nM
Beside the measured number, compound 4's estimate is 1.5-fold (0.18 log units) above it, within the range that was stated.
By their numbers in this assay, from the lowest: compounds 2, 4, 1 and 3 (each within the scatter of the next).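

In this assay the exchange of 4-fluorophenyl for 4-methoxyphenyl now gives a 1.9-fold lower number from compound 3 to compound 4 (0.27 log units; within the scatter) and so has been read on two cores, both times within the scatter: the same change on two cores in this assay, a 1.3-fold lower number (0.10 log units; within the scatter) from compound 1 to compound 2 and a 1.9-fold lower number (0.27 log units; within the scatter) from compound 3 to compound 4, 1.5-fold (0.17 log units) apart, within the scatter of two such steps. The exchange of piperidin-1-yl for pyrrolidin-1-yl, now also read as no change at the digits printed from compound 2 to compound 4 (within the scatter) on a second core, likewise stays within the scatter: the same change on two cores in this assay, a 1.5-fold higher number (0.17 log units; within the scatter) from compound 1 to compound 3 and no change at the digits printed (within the scatter) from compound 2 to compound 4, 1.5-fold (0.17 log units) apart, within the scatter of two such steps. Across these four compounds, neither change moves the number clearly at either place.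

From the compounds shown here alone, it remains open whether any group at this aromatic carbon, such as a carboxylic acid or an amine in place of the methoxy, would move the number beyond the scatter. Going by these compounds, it is equally open whether a longer chain carrying the pyrrolidin-1-yl would do so.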